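This account rests on a few compounds, and the source may have more. Where it says the series, first, only, none or still open, it means among the compounds named here.

Values in a functional assay on Ramos cells (Homo sapiens) for antiproliferative activity, read by CCK-8 assay, with a stated time of 48 h; on this read-out lower numbers stand for stronger inhibition and higher numbers for weaker inhibition:
compound 1 `C=CC(=O)Nc1cccc(Nc2nc(Nc3ccc(OCC(=O)N(CCOC)CCOC)cc3)ncc2Cl)c1`: 18100 nM
compound 2 `C=CC(=O)Nc1cccc(Nc2nc(Nc3ccc(OCC(=O)N(CCOC)CCOC)c(Cl)c3)ncc2Cl)c1`: 16900 nM
compound 3 `C=CC(=O)Nc1cccc(Nc2nc(Nc3ccc(OCC4CCCO4)cc3)ncc2F)c1`: 22300 nM

Compound 1 stands in one band with compound 2 and compound 3. The three numbers lie within the scatter of each other, so they give no ranking.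

Next in the series is compound 4 `C=CC(=O)Nc1cccc(Nc2nc(Nc3ccc(OCC(=O)OCC4CCCO4)cc3)ncc2Cl)c1`, which differs from compound 1 as follows: (oxolan-2-yl)methoxy in place of bis(2-methoxyethyl)amino on a carbonyl carbon. In words, (oxolan-2-yl)methoxy replaces bis(2-methoxyethyl)amino on a carbonyl carbon.

For the measured compounds named here, no measured step covers this change. Going by the values given here, the only measured step is a 1.1-fold lower number from compound 1 to compound 2 (0.03 log units; within the scatter), a chloro in place of hydrogen on an aromatic carbon. It lies within the scatter and bears on the present change only indirectly, as a sign that the numbers have so far moved little. The entering group also occurs in compound 3, which gives 22300 nM, in the same band as compound 1 despite other structural differences. Among the compounds with values here, this is weak support from only three compounds, and the range is kept wide to reflect that.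

No shift beyond the scatter is expected in this assay, and no direction is favoured. The expected step is a 1.0-fold higher number from compound 1 to compound 4 (0.02 log units; within the scatter). For compound 4 the estimated value is 19000 nM, with an expected range of 9000 nM to 40000 nM.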

Compound 4, half-maximal inhibitory concentration: > 40000 nM
Compound 4: a limit, no number; the forecaster's own chance of this, stated with the estimate: 10%; at least 2.1-fold (0.32 log units) between middle value and limit.
By their numbers in this assay, from the lowest: compounds 2, 1 and 3 (each within the scatter of the next). At a limit, above all of these: compound 4.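

In this assay compound 4 gives > 40000 nM, which is a limit of the assay and not a number. For the compounds shown here, the change on the carbonyl carbon gives an at least 2.2-fold higher number from compound 1 to compound 4 (0.34 log units; beyond the scatter), the first step to lie beyond the scatter, whereas the chloro change gives a 1.1-fold lower number from compound 1 to compound 2 (0.03 log units; within the scatter), so the group on this carbon can move the read-out in a way the earlier step did not show. Bis(2-methoxyethyl)amino and (oxolan-2-yl)methoxy have the same counts of hydrogen-bond donors and acceptors and no net charge, so these counts do not separate the two groups, and the step has only a lower bound: the limit of > 40000 nM in this assay, at which 1 of the 4 values shown sits.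

The change replaces the nitrogen on the carbonyl carbon with oxygen and the open chains with a five-membered ring in a single move, so the compounds shown leave open which of these goes with the step. An (oxolan-2-yl)methylamino group or a 2-methoxyethoxy group on the same carbonyl carbon would separate the two parts of the change, and a number for compound 4 would be needed to fix the size of the step.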